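Swapping a triazole side chain for a piperazine chain

A few compounds are considered here, and "the series" means these few. Any claim that something is new, unique, unknown or untested is made for them only; others in the source may bear on it.

In a functional assay on HCT-116 cells (Homo sapiens) for cytotoxicity, read by MTT assay, with a stated time of 72 h (on this read-out lower numbers stand for stronger inhibition and higher numbers for weaker inhibition), compound 3 `O=C1c2c[n+]([O-])c3ccccc3c2C(=O)c2c1c1ccccc1n2Cc1cn(C[C@H](O)CO)nn1` gives 400 nM as its measured value, while compound 1 `O=C1c2c[n+]([O-])c3ccccc3c2C(=O)c2c1c1ccccc1n2Cc1cn([C@H]2O[C@H](CO)[C@@H](O)[C@H]2O)nn1` gives 710 nM and compound 2 `O=C1c2c[n+]([O-])c3ccccc3c2C(=O)c2c1c1ccccc1n2Cc1cn([C@@H]2C[C@H](O)[C@@H](CO)O2)nn1` gives 50 nM on the same scale. Compound 3 thus sits with compound 1, within the scatter, and clearly apart from compound 2. Compound 4 `O=C1c2c[n+]([O-])c3ccccc3c2C(=O)c2c1c1ccccc1n2CCCCN1CCNCC1` alters the side chain on the shared core: the change 3-(piperazin-1-yl)propyl in place of 1-(2,3-dihydroxypropyl)-1H-1,2,3-triazol-4-yl on a saturated chain carbon bound to an aromatic nitrogen puts 3-(piperazin-1-yl)propyl in place of 1-(2,3-dihydroxypropyl)-1H-1,2,3-triazol-4-yl on a saturated chain carbon bound to an aromatic nitrogen. The measured steps offer only indirect guidance, as all three compounds keep the triazole: a 14-fold lower number from compound 1 to compound 2 (1.15 log units; beyond the scatter) is large, a 1.8-fold lower number from compound 1 to compound 3 (0.25 log units; within the scatter) lies within the scatter, and an 8.0-fold higher number from compound 2 to compound 3 (0.90 log units; beyond the scatter) is modest. Within the data shown here, no measured compound carries a piperazine, so the direction remains uncertain. A modest move toward lower numbers is tentatively expected, estimated as a 2.0-fold lower number from compound 3 to compound 4 (0.30 log units; within the scatter) in this assay (with wide uncertainty). Compound 4 is expected near 200 nM (estimated range 40 nM to 1000 nM).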

Compound 4, half-maximal inhibitory concentration: 700 nM
Compound 4: middle estimate off by 3.5-fold (0.54 log units), on the low side; the range from low to high includes it.
By their numbers in this assay, from the lowest: compound 2; then compounds 3, 4 and 1 (each within the scatter of the next).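

In this assay the swap to the piperazine chain gives a 1.8-fold higher number from compound 3 to compound 4 (0.24 log units; within the scatter), so this read-out does not separate the two side chains. Compounds 1, 2 and 3 all keep the triazole and differ only in what it carries, whereas compound 4 has no triazole, no hydroxy groups and a six-membered non-aromatic ring at the end of its chain. This position on the shared core can therefore hold a 4-(piperazin-1-yl)butyl group in place of the (1-(2,3-dihydroxypropyl)-1H-1,2,3-triazol-4-yl)methyl group with no change beyond the scatter, and no measurement is available to explain this.

Chain and ring change together here, so their separate contributions remain unknown. A morpholine ring on the same chain, or a piperazine on a shorter chain, would help to pull them apart.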